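Methyl for Chloro in a Sparingly Soluble Acid

The source may hold more compounds than are shown below. What is called first, only, known or untested is meant among the compounds shown, and "the series" means these compounds.

The set rests on compound 1 `O=C(O)c1ccc(-n2cc(C(=O)c3c(Cl)cccc3Cl)c3cccnc32)cc1`, which in a physicochemical assay for solubility, at pH 4 (a lower number here means a less soluble compound, a higher number a more soluble compound), gives 3000 nM. Compound 2 `O=C(O)c1ccc(-n2cc(C(=O)c3c(Cl)cccc3Cl)c3cccnc32)c(F)c1` differs from it by fluoro in place of hydrogen on an aromatic carbon. In this assay compound 2 gives < 1000 nM, a limit of the assay and not a number. The step of an at least 3.0-fold lower number from compound 1 to compound 2 (0.47 log units; beyond the scatter) is therefore known only as a lower bound, since compound 2 sits at the limit of < 1000 nM in this assay, at which 1 of the 2 values shown sits. Where compound 2 stands on solubility is thus only a ceiling, not a point.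

Compound 3 `Cc1cccc(Cl)c1C(=O)c1cn(-c2ccc(C(=O)O)cc2F)c2ncccc12` is the next step, differing from compound 2 by methyl in place of chloro on an aromatic carbon. For the measured compounds named here, no measured step in this set exchanges methyl for chloro; the one step on record, fluoro for hydrogen, sits elsewhere on the molecule and offers no guide here. With nothing to point either way, the expected change in this assay is none beyond the scatter, a step that the limit leaves unreadable from compound 2 to compound 3. Compound 3 is accordingly estimated at 800 nM, within a range of 300 nM to 2500 nM, with a fair chance the assay again reports only a limit.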

Compound 3, solubility: 1000 nM
Compound 3: the middle estimate sits 1.3-fold (0.10 log units) below what was measured; measured number inside the range.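

In this assay compound 3 gives 1000 nM as a number, so with the change from 2,6-dichlorophenyl to 2-chloro-6-methylphenyl the series carrying the fluoro group gains its first value that is not a limit. Compound 2 gives < 1000 nM, which is a limit of the assay and not a number. The exchange of methyl for chloro at this position therefore reads as a direction only, a number no lower from compound 2 to compound 3 (the limit leaves the size open), and its size cannot be read because one end of the step is a limit: the limit of < 1000 nM in this assay, at which 1 of the 3 values shown sits.

On these data alone, it remains open how the same exchange would read on compound 1, which carries hydrogen where compound 3 carries fluoro, and how a compound with methyl in place of the remaining chloro would stand. Also open, as far as these compounds go, is how other groups at this place on the ring, such as methoxy, trifluoromethyl or an amine, would stand in this assay against compound 3.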